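Working notes: from compound 3 to compound 4

The source may hold more compounds than are shown below. What is called first, only, known or untested is meant among the compounds shown, and "the series" means these compounds.

In a physicochemical assay for solubility, in phosphate buffer, at pH 7.4 (a lower number here means a less soluble compound, a higher number a more soluble compound), compound 1 `OC1CCN(c2nccnc2OC2CN(c3ccc4ccccc4n3)C2)CC1` gives 99000 nM and compound 2 `N#CC1CCN(c2nccnc2OC2CN(c3ccc4ccccc4n3)C2)CC1` gives 66000 nM while compound 3 `c1ccc2nc(N3CC(Oc4nccnc4-c4ccncc4)C3)ccc2c1` gives 56000 nM on the same scale. Compound 3 thus lies within the scatter of both others, and the three numbers cannot be ranked.

Compound 4 `Cc1ncccc1-c1nccnc1OC1CN(c2ccc3ccccc3n2)C1` has 2-methylpyridin-3-yl in place of pyridin-4-yl on an aromatic carbon, and 2-methylpyridin-3-yl in place of pyridin-4-yl on an aromatic carbon gives the counted difference.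

Among the measured compounds shown here, no measured compound carries this group, so no direct precedent exists. The nearest evidence is a 1.8-fold lower number from compound 1 to compound 3 (0.25 log units; within the scatter) and a 1.2-fold lower number from compound 2 to compound 3 (0.07 log units; within the scatter) at the same aromatic carbon, along with a 1.5-fold lower number from compound 1 to compound 2 (0.18 log units; within the scatter) on a saturated ring carbon. Since exchange at that aromatic carbon gave only a 1.8-fold lower number from compound 1 to compound 3 (0.25 log units; within the scatter) in these data, no step beyond the scatter is expected in this assay for the smaller change here. The estimate amounts to a 1.1-fold lower number from compound 3 to compound 4 (0.05 log units; within the scatter) with no direction expected to stand out.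

Compound 4 is expected at 50000 nM with 22000 nM to 105000 nM as its estimated range.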

Compound 4, solubility: 253000 nM
Compound 4: middle estimate off by 5.1-fold (0.70 log units), on the low side; measured number outside the range, above it.
By their numbers in this assay, from the lowest: compounds 3, 2 and 1 (each within the scatter of the next); then compound 4.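

At this aromatic carbon, next to the ring nitrogen, the three earlier groups could not be told apart in this assay, but 2-methylpyridin-3-yl stands clear of all of them: of pyridin-4-yl (a 4.5-fold higher number from compound 3 to compound 4 (0.65 log units; beyond the scatter)), of 4-cyanopiperidin-1-yl (a 3.8-fold higher number from compound 2 to compound 4 (0.58 log units; beyond the scatter)) and of 4-hydroxypiperidin-1-yl (a 2.6-fold higher number from compound 1 to compound 4 (0.41 log units; beyond the scatter)). The position therefore does respond to exchange, even though the entering group keeps the one six-membered aromatic ring with 1 hetero atom that pyridin-4-yl has. The data on hand give no explanation for this step.

The compounds shown do not separate the methyl from the move from a pyridin-4-yl to a pyridin-3-yl attachment, which plain pyridin-3-yl would address. Also open, from the compounds shown here alone, is how an aminomethyl group or a carboxylic acid on that ring would read.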